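Dropping the Fluoro Substituent from Compound 1

The source may hold more compounds than are shown below. What is called first, only, known or untested is meant among the compounds shown, and "the series" means these compounds.

Compound 1, `Fc1cccc(-c2n[nH]cc2N2CCCNCC2)c1`: in an assay on isolated protein for binding affinity to 5-hydroxytryptamine receptor 3A (Homo sapiens) (on this read-out lower numbers stand for stronger inhibition and higher numbers for weaker inhibition), compound 1 gives 656 nM.
Compound 2, `COc1ccccc1-c1n[nH]cc1N1CCCNCC1`: in this assay compound 2 gives 2230 nM.

Compound 1 holds the lower of the two numbers, and compound 2 sits higher by a gap that lies beyond the scatter. Compound 3, `c1ccc(-c2n[nH]cc2N2CCCNCC2)cc1`, differs from compound 1 in one place: hydrogen in place of fluoro on an aromatic carbon. Going by the values given here, no measured pair shows this change, so the expected step from compound 1 to compound 3 is a 1.5-fold higher number from compound 1 to compound 3 (0.18 log units; within the scatter), judged small, toward a somewhat higher number, and likely within the scatter. Compound 3 is therefore estimated at 1000 nM, in a range from 400 nM to 2500 nM.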

Compound 3, inhibition constant: 2100 nM
The estimate for compound 3 lay 2.1-fold (0.32 log units) below the measured number; measured number inside the range.
By their numbers in this assay, from the lowest: compound 1; then compounds 3 and 2 (each within the scatter of the next).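

In this assay, the fluoro group on this aromatic carbon, meta to a large group, turns out to matter: hydrogen in its place gives a 3.2-fold higher number from compound 1 to compound 3 (0.51 log units; beyond the scatter). Hydrogen in place of methoxy on an aromatic carbon gives a 1.1-fold lower number from compound 2 to compound 3 (0.03 log units; within the scatter), so only the fluoro compound stands apart from the unsubstituted one. Nothing available here explains this difference. Going by these compounds, whether chloro, hydroxy or an amine on the same carbon would match fluoro remains open, as does what fluoro would do on another carbon of that ring.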